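The source may report more compounds than this note shows. Statements on the series, on what has been measured and on what is new or still open speak of the compounds shown alone.

Compound 1, `Cc1ccc(Nc2nc(N)c(C(=O)c3ccccc3)s2)cc1`, gives 900 nM in a functional assay on HeLa cells (Homo sapiens) for antiproliferative activity, read by cell counting, with a stated time of 2 days; a lower number here means a stronger inhibitor, a higher number a weaker inhibitor.
Compound 2, `COc1ccc(Nc2nc(N)c(C(=O)c3ccccc3)s2)cc1`, gives 230 nM.
Compound 3, `Nc1nc(Nc2ccc(Cl)cc2)sc1C(=O)c1ccccc1`, gives > 10000 nM, which is a limit of the assay rather than a number.

Of the two numbers shown, compound 2 stands lowest; the step of a 3.9-fold lower number from compound 1 to compound 2 (0.59 log units; beyond the scatter) is beyond the scatter. The step of an at least 11-fold higher number from compound 1 to compound 3 (1.04 log units; beyond the scatter) and the step of an at least 43-fold higher number from compound 2 to compound 3 (1.63 log units; beyond the scatter) both run up to the limit (the limit of > 10000 nM in this assay, at which 1 of the 3 values shown sits), so their true size is not known, only that they are large. All three of these measured changes sit at a single place on the shared core: one aromatic carbon, where methyl, methoxy and chloro are exchanged for one another.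

Compound 4, `COc1ccc(Nc2nc(N)c(C(=O)c3ccc([N+](=O)[O-])cc3)s2)cc1`, differs from compound 2 at a different place: nitro in place of hydrogen on an aromatic carbon. That ring is left untouched by every measured step, and none of them gives a guide to this change, in either direction. The expectation is no step beyond the scatter, with a wide range to allow for the lack of any precedent. Compound 4 is therefore estimated to give 230 nM, within 60 nM to 900 nM. This estimate amounts to an expected step of no change at the digits printed from compound 2 to compound 4 (within the scatter).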

Compound 4, half-maximal inhibitory concentration: 350 nM
For compound 4 the middle estimate is 1.5-fold (0.18 log units) below the measured one, and the stated range covers the measured number.
By their numbers in this assay, from the lowest: compounds 2 and 4 (each within the scatter of the next); then compound 1. At a limit, above all of these: compound 3.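

Among the compounds shown here, the earlier compounds varied only one other aromatic carbon, so this is the first reading on this six-membered aromatic ring of carbon only. In this assay the result is a 1.5-fold higher number from compound 2 to compound 4 (0.18 log units; within the scatter), so nitro, with its 3 heavy atoms, can stand in place of hydrogen here, para to a large group, without a change that can be told from the scatter. That differs from the exchanges at the earlier place, where even the smallest readable step, a 3.9-fold lower number from compound 1 to compound 2 (0.59 log units; beyond the scatter), lies beyond the scatter, although nothing shown here explains why the two places differ.

A single group at a single carbon of this ring cannot show whether the position accepts substitution in general, and an amine, a carboxylic acid or a longer chain there might give a quite different number. As far as these compounds go, it also remains open whether nitro at this place would give a similar result on the core of compound 1, which carries methyl rather than methoxy at the earlier position.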